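A few compounds are considered here, and "the series" means these few. Any claim that something is new, unique, unknown or untested is made for them only; others in the source may bear on it.

Compound 3 `O=[N+]([O-])c1ccc(N2CC[C@H]3CN[C@H]3C2)cn1` gives 390 nM in a functional assay on HEK293 cells for agonist activity at Neuronal acetylcholine receptor; alpha3/beta4 (Homo sapiens), read by FLIPR (on this read-out lower numbers stand for an effect already at smaller amounts and higher numbers for an effect only at larger amounts of compound), the second highest of the three numbers: compound 1 `c1cncc(N2CC[C@@H]3CN[C@@H]3C2)c1` gives 260 nM, within the scatter of compound 3, while compound 2 `COc1ccc(N2CC[C@@H]3CN[C@@H]3C2)cn1` gives 2400 nM, beyond it. Within the data shown here, the one step measured so far, a 9.2-fold higher number from compound 1 to compound 2 (0.97 log units; beyond the scatter), concerns a substituent on the aromatic ring and does not bear on configuration. Compound 4 `O=[N+]([O-])c1ccc(N2CC[C@@H]3CN[C@@H]3C2)cn1` differs from compound 3 only in configuration: the two compounds have the same atoms and bonds and differ only in configuration as drawn: 2 of 2 stereo elements differ (all stereocentres are inverted: mirror images); a stereocentre at a saturated ring carbon is drawn S in compound 3 and R in compound 4; a stereocentre at a saturated ring carbon is drawn R in compound 3 and S in compound 4. Among the measured compounds shown here, no measured pair shows the effect of inverting both ring stereocentres, so the direction of the step in this assay is open. For compound 4 a value of 700 nM is estimated, between 100 nM and 5000 nM, meaning an expected step of a 1.8-fold higher number from compound 3 to compound 4 (0.25 log units; within the scatter), with a wide range.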

Compound 4, half-maximal effective concentration: 830 nM
Beside the measured number, compound 4's estimate is 1.2-fold (0.07 log units) below it; the range from low to high includes it.
By their numbers in this assay, from the lowest: compounds 1 and 3 (each within the scatter of the next); then compound 4; then compound 2.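

In this assay, among these compounds, the first configurational step is small but beyond the scatter, a 2.1-fold higher number from compound 3 to compound 4 (0.33 log units; beyond the scatter), and it can be assigned to configuration alone because of this: the fact that compounds 3 and 4 differ only in the configuration as drawn. Within one configuration, the aromatic substituent can now be read through two further steps, a 2.9-fold lower number from compound 2 to compound 4 (0.46 log units; beyond the scatter) and a 3.2-fold higher number from compound 1 to compound 4 (0.50 log units; beyond the scatter). Together with the earlier methoxy step, this puts nitro in the middle, with numbers rising from hydrogen through nitro to methoxy.

The compounds shown leave open whether inversion gives a similar step with hydrogen or methoxy on the aromatic carbon. Going by these compounds, how an amine or a carboxylic acid would read in that place also remains open.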